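Taking one methoxy away from compound 3

The source may report more compounds than this note shows. Statements on the series, on what has been measured and on what is new or still open speak of the compounds shown alone.

In a functional assay on EA.hy 926 cells (Homo sapiens) for cytotoxicity, read by MTT assay, with stated times of 24 h and 12 h (a lower number here means that less compound is needed, a higher number that more compound is needed for the effect), compound 1 `COc1cc(/C=C/C(=O)O)ccc1OC(=O)c1nc(C)c(C)nc1C` gives 69400 nM and compound 2 `CCOC(=O)/C=C/c1ccc(OC(=O)c2nc(C)c(C)nc2C)c(O)c1` gives 1700 nM while compound 3 `CCOC(=O)/C=C/c1cc(OC)c(OC(=O)c2nc(C)c(C)nc2C)c(OC)c1` gives 21400 nM as its reading. Compound 3 therefore holds the second highest of the three numbers. Compound 1 needs more compound for the effect and compound 2 needs less, and both gaps lie beyond the scatter of repeated measurements.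

The next molecule, compound 4 `CCOC(=O)/C=C/c1ccc(OC(=O)c2nc(C)c(C)nc2C)c(OC)c1`, comes from compound 3 by one small edit: hydrogen in place of methoxy on an aromatic carbon ortho to a large group. Going by the values given here, no two measured compounds differ in only one place, so no measured step shows what such a swap does, and any forecast here is rough. Among the compounds with values here, the only guide is the spread of the values. Compound 2 at 1700 nM shows that a number well under that of compound 3 is possible among these compounds. A moderate move toward a lower number in this assay is therefore expected, somewhat beyond the scatter. The estimated step of a 2.7-fold lower number from compound 3 to compound 4 (0.43 log units; beyond the scatter) is modest next to the full spread. For compound 4 the estimated value is 8000 nM with an expected range from 2500 nM to 25000 nM once measured.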

Compound 4, half-maximal effective concentration: 38600 nM
Compound 4: the middle estimate sits 4.8-fold (0.68 log units) below what was measured, outside the stated range (above it).
By their numbers in this assay, from the lowest: compound 2; then compounds 3, 4 and 1 (each within the scatter of the next, the first and the last beyond it).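

Measured in this assay and set against the usual scatter, hydrogen in place of methoxy on this aromatic carbon, ortho to a large group, gives a step that cannot be told from repeat noise (a 1.8-fold higher number from compound 3 to compound 4 (0.26 log units; within the scatter)), so the data show no clear effect of this methoxy here. The oxygen on the aromatic ring behaves quite differently, as methyl in place of hydrogen there gives a large step, well beyond the scatter (a 23-fold higher number from compound 2 to compound 4 (1.36 log units; beyond the scatter)), and among the compounds shown this is the one single edit with a clear effect. Ethyl in place of hydrogen on the oxygen next to a carbonyl group also stays within the scatter (a 1.8-fold lower number from compound 1 to compound 4 (0.25 log units; within the scatter)), so the ethyl ester and the carboxylic acid cannot be separated in this assay.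

No measurement given here accounts for any of these steps. As far as these compounds go, it remains open what an amine or a longer chain such as propoxy would give on the aromatic carbon in question, and whether a longer chain on the oxygen on the aromatic ring would follow the methyl result.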